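Bringing a hydroxyl back onto the alkyne chain

The compounds below may be only part of what the source reports. "The series", "measured", "known", "first", "only" and "open" are said of these compounds alone.

For the measured compounds named here, in a functional assay on KG-1 cells (Homo sapiens) for antiproliferative activity (a higher number here means that more compound is needed for the effect, a lower number that less compound is needed), compound 2 `CC1(CC#Cc2c(Cl)c3c(Cl)cc(C(N)=O)nc3n2[C@H]2CCCNC2)COC1` gives 289 nM, the highest of the two numbers known so far, while compound 1 `NC(=O)c1cc(Cl)c2c(Cl)c(C#CCCO)n([C@H]3CCCNC3)c2n1` gives 56 nM. Going by the values given here, the single measured step, a 5.2-fold higher number from compound 1 to compound 2 (0.71 log units; beyond the scatter), accompanied the exchange of a hydroxymethyl for the oxetane. Compound 3 `CC(O)CC#Cc1c(Cl)c2c(Cl)cc(C(N)=O)nc2n1[C@H]1CCCNC1` differs from compound 2 by 1-hydroxyethyl in place of 3-methyloxetan-3-yl on a saturated chain carbon bound to a triple-bonded carbon, which restores a hydroxyl group on that chain. Because that earlier step a 5.2-fold higher number from compound 1 to compound 2 (0.71 log units; beyond the scatter) ran in the opposite direction, compound 3 is expected to move back toward compound 1, by roughly a 3.2-fold lower number from compound 2 to compound 3 (0.51 log units; beyond the scatter). In this assay compound 3 is estimated at 90 nM, within a range of 35 nM to 250 nM.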

Compound 3, half-maximal effective concentration: 48 nM
Compound 3: the middle estimate sits 1.9-fold (0.27 log units) above what was measured, within the range that was stated.
By their numbers in this assay, from the lowest: compounds 3 and 1 (each within the scatter of the next); then compound 2.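

In this assay, 1-hydroxyethyl in place of 3-methyloxetan-3-yl on a saturated chain carbon bound to a triple-bonded carbon gives (a 6.0-fold lower number from compound 2 to compound 3 (0.78 log units; beyond the scatter)), so an open-chain hydroxyl recovers what the oxetane lost. The methyl added to the hydroxyl-bearing chain carbon makes no difference that can be told from scatter (a 1.2-fold lower number from compound 1 to compound 3 (0.07 log units; within the scatter)), so this position accepts that extra methyl. Nothing shown here explains either step.

On these data alone, what an amine, a carboxylic acid or a longer chain would give at this place remains open. As far as these compounds go, whether the two mirror forms of 2-hydroxypropyl differ also remains open.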